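Piperidin-1-yl in Place of 4-methylpiperazin-1-yl on Compound 1

The source may report more compounds than this note shows. Statements on the series, on what has been measured and on what is new or still open speak of the compounds shown alone.

Compound 1 (`CCCCCCCCCCCCCCCCOP(=O)(O)OCCSC(=S)N1CCN(C)CC1`) gives 49300 nM in a functional assay on DU-145 cells (Homo sapiens) for inhibition, read by MTT assay, with stated times of 18 h and 4 h (on this read-out lower numbers stand for stronger inhibition and higher numbers for weaker inhibition), and stands within the scatter of compound 2 (`CCCCCCCCCCOP(=O)(O)OCCSC(=S)N1CCN(C)CC1`), which gives 82300 nM there. Compound 3 (`CCCCCCCCOP(=O)(O)OCCSC(=S)N1CCN(C)CC1`) reads > 100000 nM as a limit of this assay and not as a number. The chain changes amount to a 1.7-fold higher number from compound 1 to compound 2 (0.22 log units; within the scatter) and an at least 2.0-fold higher number from compound 1 to compound 3 (0.30 log units; that floor lies within the scatter) and leave the ring untouched, so they set no size for the next change. The move to compound 4 (`CCCCCCCCCCCCCCCCOP(=O)(O)OCCSC(=S)N1CCCCC1`) is piperidin-1-yl in place of 4-methylpiperazin-1-yl on a thiocarbonyl carbon with piperidin-1-yl in place of 4-methylpiperazin-1-yl on a thiocarbonyl carbon. No shift beyond the scatter is expected in this assay and the estimated change is a 1.2-fold lower number from compound 1 to compound 4 (0.07 log units; within the scatter) in either direction. For compound 4 the estimate is 42000 nM with an expected range from 17000 nM to 95000 nM as its half-maximal inhibitory concentration.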

Compound 4, half-maximal inhibitory concentration: 14700 nM
Compound 4: middle estimate off by 2.9-fold (0.46 log units), on the high side, outside the stated range (below it).
By their numbers in this assay, from the lowest: compound 4; then compounds 1 and 2 (each within the scatter of the next). At a limit, above all of these: compound 3.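

In this assay, the group on the thiocarbonyl carbon proves able to move the number with the chain of compound 1 held fixed. Piperidin-1-yl in place of 4-methylpiperazin-1-yl gives a 3.4-fold lower number from compound 1 to compound 4 (0.53 log units; beyond the scatter) and is the first step shown that reads as beyond the scatter.

As far as these compounds go, whether morpholin-4-yl or pyrrolidin-1-yl at this place would read like piperidin-1-yl stays open, as does whether the step carries over to the shorter chains of compound 2 and compound 3. Nothing given here explains the step.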